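The source may report more compounds than this note shows. Statements on the series, on what has been measured and on what is new or still open speak of the compounds shown alone.

Compound 1 `Nc1n[nH]c2cc(-c3cn([C@@H]4CN[C@H](C(=O)Nc5ccc(Cl)cc5Cl)C4)nn3)ccc12` and compound 2 `CC(=O)Nc1n[nH]c2cc(-c3cn([C@@H]4CN[C@H](C(=O)Nc5ccc(Cl)cc5Cl)C4)nn3)ccc12` share one core, while compound 3 `Nc1nc2ccc(-c3cn([C@@H]4CN[C@H](C(=O)Nc5ccc(Cl)c(C(F)(F)F)c5)C4)nn3)nc2s1` and compound 4 `CC(=O)Nc1nc2ccc(-c3cn([C@@H]4CN[C@H](C(=O)Nc5ccc(Cl)c(C(F)(F)F)c5)C4)nn3)nc2s1` share another; the difference between the two cores is not broken down here. The three measured compounds were tested in a functional assay on K562 cells (Homo sapiens) for inhibition, read by MTT assay, with a stated time of 48 h; on this read-out higher numbers stand for weaker inhibition and lower numbers for stronger inhibition. In this assay compound 1 gives 28400 nM. Compound 2 differs from compound 1 by the change acetyl in place of hydrogen on a nitrogen on an aromatic ring and in this assay compound 2 gives 2090 nM. That single change produced the step of a 14-fold lower number from compound 1 to compound 2 (1.13 log units; beyond the scatter). Compound 3 in this assay gives 26200 nM, a number that sits close to that of compound 1. Compound 4 differs from compound 3 by the change (acetyl in place of hydrogen on a nitrogen on an aromatic ring), at the same place as before, so it is the same change seen a second time, now on the other core. The outcome of that change on this core has not yet been measured. Because the step of a 14-fold lower number from compound 1 to compound 2 (1.13 log units; beyond the scatter) was large and came from one change alone, a step in the same direction is expected here, estimated as an 8.7-fold lower number from compound 3 to compound 4 (0.94 log units; beyond the scatter), although this rests on a single earlier example and a smaller step would not be surprising. On that basis compound 4 is expected to give 3000 nM in this assay, with the estimate spanning from 900 nM to 10000 nM.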

Compound 4, half-maximal inhibitory concentration: 10000 nM
Compound 4: the middle estimate sits 3.3-fold (0.52 log units) below what was measured; the measured number falls inside the stated range.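

In this assay, acetyl in place of hydrogen on a nitrogen on an aromatic ring again lowers the number on the second core, giving a 2.6-fold lower number from compound 3 to compound 4 (0.42 log units; beyond the scatter), so the direction of the earlier step carries over, which means stronger inhibition on both cores. The size of the step does not carry over, and the two steps differ by more than repeated measurements would explain: the same change on two cores in this assay, a 14-fold lower number (1.13 log units; beyond the scatter) from compound 1 to compound 2 and a 2.6-fold lower number (0.42 log units; beyond the scatter) from compound 3 to compound 4, 5.2-fold (0.71 log units) apart, beyond the scatter of two such steps. This shows that the change can be expected to help in this small set but that its gain on one core is not a reliable measure of its gain on another; it does not show why the gain differs, since the two pairs differ in more than one place, and two pairs cannot establish a general rule for the series.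

The compounds shown leave open how a longer acyl chain such as propionyl, or a simple methyl group, on that same nitrogen would compare with acetyl on either core. They also leave open whether the same direction would appear on a third core.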